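This account rests on a few compounds, and the source may have more. Where it says the series, first, only, none or still open, it means among the compounds named here.

Compound 1 `O=C(Nc1c(C(O)(C(F)(F)F)C(F)(F)F)ccc2ccccc12)c1ccccc1` gives 44 nM in an assay on LtK cells with ATP-sensitive inward rectifier potassium channel 11 (Homo sapiens) as the target; on this read-out higher numbers stand for an effect only at larger amounts of compound and lower numbers for an effect already at smaller amounts. Compound 2 `O=C(Nc1c(C(O)(C(F)(F)F)C(F)(F)F)ccc2ccccc12)c1cccc([N+](=O)[O-])c1` gives 117 nM, and a 2.7-fold higher number from compound 1 to compound 2 (0.42 log units; beyond the scatter); compound 2 thus stands at the higher of the two numbers measured. The next change, (4-(trifluoromethyl)phenyl in place of 3-nitrophenyl on a carbonyl carbon), gives compound 3 `O=C(Nc1c(C(O)(C(F)(F)F)C(F)(F)F)ccc2ccccc12)c1ccc(C(F)(F)F)cc1`. Among the measured compounds shown here, only the step from compound 1 to compound 2 bears on it, and it concerns the nitro group alone; nothing measured speaks to the trifluoromethyl. The expected step is therefore a 1.7-fold lower number from compound 2 to compound 3 (0.22 log units; within the scatter), a return toward the number of compound 1 with wide uncertainty. Compound 3 is estimated at 70 nM, between 25 nM and 200 nM.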

Compound 3, half-maximal effective concentration: 160 nM
For compound 3 the middle estimate is 2.3-fold (0.36 log units) below the measured one; the measured number falls inside the stated range.
By their numbers in this assay, from the lowest: compound 1; then compounds 2 and 3 (each within the scatter of the next).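

On the carbonyl carbon, 4-(trifluoromethyl)phenyl and 3-nitrophenyl are not told apart in this assay, with a 1.4-fold higher number from compound 2 to compound 3 (0.14 log units; within the scatter). Trifluoromethyl in place of hydrogen gives a 3.6-fold higher number from compound 1 to compound 3 (0.56 log units; beyond the scatter), so a second substituent, not only nitro, stands beyond the scatter of the unsubstituted phenyl of compound 1. No available evidence accounts for either step.

As far as these compounds go, it remains open whether an amine, a methoxy group or a carboxylic acid on this phenyl ring would match compound 1 or compounds 2 and 3. Also open, from the compounds shown here alone, is how the nitro and trifluoromethyl groups would read at other ring positions.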